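Compound 3 to compound 4: vinylcarbonyl on the ring nitrogen

A few compounds are considered here, and "the series" means these few. Any claim that something is new, unique, unknown or untested is made for them only; others in the source may bear on it.

Compound 1 (`CNC(=O)/C=C/CN1CC(Oc2ccc(Oc3c(-c4ccc(F)cc4)sc4cc(O)ccc34)cc2)C1`) gives > 50000 nM in a functional assay on MDA-MB-231 cells (Homo sapiens) for antiproliferative activity, read by CCK-8 assay, with a stated time of 48 h (a lower number here means a stronger inhibitor, a higher number a weaker inhibitor), which is a limit and not a number. Compound 2 (`CN(C)C(=O)/C=C/CNCCOc1ccc(Oc2c(-c3ccc(F)cc3)sc3cc(O)ccc23)cc1`) gives > 50000 nM, again a limit. Compound 3 (`CN(C)C(=O)/C=C/CN1CC(Oc2ccc(Oc3c(-c4ccc(F)cc4)sc4cc(O)ccc34)cc2)C1`) gives > 50000 nM, also a limit. Within the data shown here, the series therefore has no numerical value so far: the limit of > 50000 nM in this assay, at which 3 of the 3 values shown sit.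

Compound 4 (`C=CC(=O)N1CC(Oc2ccc(Oc3c(-c4ccc(F)cc4)sc4cc(O)ccc34)cc2)C1`) carries vinylcarbonyl in place of 3-(dimethylcarbamoyl)prop-2-en-1-yl on an amine nitrogen in a ring.

Among the measured compounds shown here, two measured steps bear on this change: a step that the two limits leave unreadable from compound 1 to compound 3, and a step that the two limits leave unreadable from compound 2 to compound 3. Neither supplies a size or a direction to carry forward, and neither alters the same group in the same way. No step beyond the scatter is therefore expected in this assay, and the expected step is an at least 1.2-fold lower number from compound 3 to compound 4 (0.09 log units; that floor lies within the scatter). This expectation rests on compound 3 with its limit of > 50000 nM. A further result at the limit is the likeliest outcome. The estimate for compound 4 is 40000 nM, with an expected range of 12000 nM to 80000 nM.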

Compound 4, half-maximal inhibitory concentration: > 50000 nM
Compound 4 gave a limit, no number; the forecaster's own chance of this, stated with the estimate: 70%; middle value at least 1.2-fold (0.09 log units) from the limit.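

No step can be read from compound 1, compound 2 or compound 3 to compound 4, and the values remain limits: the limit of > 50000 nM in this assay, at which 4 of the 4 values shown sit.

The compounds shown leave open whether vinylcarbonyl, 3-(dimethylcarbamoyl)prop-2-en-1-yl and 3-(methylcarbamoyl)prop-2-en-1-yl differ at all in this assay.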